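A few compounds are considered here, and "the series" means these few. Any claim that something is new, unique, unknown or untested is made for them only; others in the source may bear on it.

Measured so far:
- compound 1 `Cc1ccc(NC(=O)c2cccc(C(F)(F)F)c2)cc1N1Cc2cnc(Nc3cnn(C)c3)nc2N(C)C1=O` gives 352 nM
- compound 2 `Cc1ccc(Nc2ncc3c(n2)N(C2CC2)C(=O)N(c2cc(NC(=O)c4ccc(C)c(C(F)(F)F)c4)ccc2C)C3)cn1` gives 649 nM
- compound 3 `Cc1ccc(Nc2ncc3c(n2)N(C)C(=O)N(c2cc(NC(=O)c4ccc(CN5CCC(N(C)C)C5)c(C(F)(F)F)c4)ccc2C)C3)cn1` gives 636 nM

All three were run in an ADME assay on BaF3 cells (Mus musculus) for inhibition, read by CellTiter-Glo, with a stated time of 72 h; on this read-out higher numbers stand for weaker inhibition of growth and lower numbers for stronger inhibition of growth. Compound 2 has the highest of the three numbers, but its nearest neighbour, compound 3, sits essentially on the same number, and even compound 1, the furthest away, lies within the usual scatter of it. No ordering among the three can therefore be claimed.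

Compound 4 `Cc1ccc(Nc2ncc3c(n2)N(C2CCCCC2)C(=O)N(c2cc(NC(=O)c4ccc(C)c(C(F)(F)F)c4)ccc2C)C3)cn1` is not yet measured. It is compound 2 with one change: cyclohexyl in place of cyclopropyl on an amide-type nitrogen in a ring

For the measured compounds named here, no pair of measured compounds differs in this one place alone, so the size of this step has no direct precedent in the set. Compound 1, which carries a smaller group on the corresponding ring nitrogen and differs elsewhere as well, gives a number that is within the scatter of compound 2, which gives no sign that this position moves the read-out strongly. The expectation for the step from compound 2 to compound 4 in this assay is therefore a small one, a 1.3-fold higher number from compound 2 to compound 4 (0.12 log units; within the scatter), most likely within the scatter, if anything towards a higher number. Compound 4 is estimated at 850 nM, with a plausible range from 300 nM to 2400 nM.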

Compound 4, concentration for 50% growth inhibition: > 5000 nM
Compound 4: no number, only a limit; the forecaster's own chance of this, stated with the estimate: 5%; middle value at least 5.8-fold (0.76 log units) away from the limit.
By their numbers in this assay, from the lowest: compounds 1, 3 and 2 (each within the scatter of the next). At a limit, above all of these: compound 4.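

At the amide-type nitrogen in the ring, the read-out does respond to the group carried: in this assay, cyclohexyl in place of cyclopropyl gives an at least 7.7-fold higher number from compound 2 to compound 4 (0.88 log units; beyond the scatter), a step beyond the scatter. The earlier compounds shown here, which differ in other places too, gave no such signal for this position. Compound 4 is known only through a limit, so the step has a floor and no upper end: the limit of > 5000 nM in this assay, at which 1 of the 4 values shown sits.

Still open, as far as these compounds go, is whether cyclobutyl or cyclopentyl on this nitrogen would read like cyclopropyl or like cyclohexyl. Also open, from the compounds shown here alone, is whether a six-membered ring holding an amine, such as piperidinyl, or an open chain such as isopropyl, would follow cyclohexyl at this place.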